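The source may report more compounds than this note shows. Statements on the series, on what has been measured and on what is new or still open speak of the compounds shown alone.

Three compounds share a core and differ only in the group on the double-bonded nitrogen. Compound 1 `CC(C)CC(C)/N=C(\NC#N)Nc1ccncc1` gives 35 mg/kg in a functional assay on the whole organism (blood, strain Wistar-Okamoto) with Rattus norvegicus as the target, with a stated time of 5 days (on this read-out higher numbers stand for an effect only at larger amounts of compound and lower numbers for an effect already at smaller amounts), compound 2 `CCC(C)C(C)/N=C(\NC#N)Nc1ccncc1` gives 8 mg/kg, and compound 3 `CC(C)(C)/N=C(\NC#N)Nc1ccncc1` gives 2.5 mg/kg, the lowest of the three numbers. The steps are a 4.4-fold lower number from compound 1 to compound 2 (0.64 log units; beyond the scatter), a 14-fold lower number from compound 1 to compound 3 (1.15 log units; beyond the scatter) and a 3.2-fold lower number from compound 2 to compound 3 (0.51 log units; beyond the scatter), so compound 3 is separated from both others by more than the scatter and is the most active of the set.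

Compound 4 `N#CN/C(=N\c1ccccc1)Nc1ccncc1` differs from compound 3 by phenyl in place of tert-butyl on a double-bonded nitrogen. Every measured step exchanges one saturated chain group for another, and none brings in a ring, so they bear on this step only loosely: within them, the more compact group gave the lower number, and phenyl has more heavy atoms than tert-butyl. A step upward beyond the scatter is therefore expected, of about a 4.0-fold higher number from compound 3 to compound 4 (0.60 log units; beyond the scatter). For compound 4 the expected value in this assay is 10 mg/kg, with a range from 3 mg/kg to 40 mg/kg.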

Compound 4, minimum effective dose: 50 mg/kg
Beside the measured number, compound 4's estimate is 5.0-fold (0.70 log units) below it; measured number outside the range, above it.
By their numbers in this assay, from the lowest: compound 3; then compound 2; then compounds 1 and 4 (each within the scatter of the next).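

Phenyl is the first ring at this position, on a double-bonded nitrogen, and it does not share the low number of tert-butyl: the exchange gives a 20-fold higher number from compound 3 to compound 4 (1.30 log units; beyond the scatter) in this assay and, measured against 1,2-dimethylbutyl, a 6.3-fold higher number from compound 2 to compound 4 (0.80 log units; beyond the scatter) as well. Against 1,3-dimethylbutyl the exchange gives only a 1.4-fold higher number from compound 1 to compound 4 (0.15 log units; within the scatter) and so leaves compound 4 level with compound 1, which shows that a six-membered aromatic ring of carbon only can land as far from tert-butyl as the furthest of the saturated chain groups. Nothing available explains this result.

With a single ring in the set, the compounds leave open whether the high number goes with the aromatic ring or with any ring. A cyclohexyl group, a benzyl group or a phenyl carrying a chlorine or a methoxy group could each fall nearer to either end of this range.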